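The source may report more compounds than this note shows. Statements on the series, on what has been measured and on what is new or still open speak of the compounds shown alone.

Compounds with numbers so far, all in a physicochemical assay for solubility, with a stated time of 18 h, at pH 7.4; on this read-out lower numbers stand for lower solubility and higher numbers for higher solubility:

- compound 1, `COc1cccc(CNCCCNc2ccnc3cc(-c4ccc(C(C)(C)C)cc4)ccc23)c1O`: 32000 nM
- compound 2, `COc1cccc(Oc2ccc3c(NCCCNCc4cccc(OC)c4O)ccnc3c2)c1`: 14500 nM
- compound 3, `COc1cccc(CNCCCNc2ccnc3cc(Cc4cccc(C(F)(F)F)c4)ccc23)c1O`: 4200 nM

Compound 1 stands highest of the three. Compound 2 sits nearest, the step being a 2.2-fold lower number from compound 1 to compound 2 (0.34 log units; beyond the scatter). Compound 3 sits furthest, the step being a 7.6-fold lower number from compound 1 to compound 3 (0.88 log units; beyond the scatter), and between those two the step is a 3.5-fold lower number from compound 2 to compound 3 (0.54 log units; beyond the scatter). All three measured steps change the group on the aromatic carbon of the shared core and leave the benzylamine end untouched.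

Compound 4, `COc1ccc(F)cc1CNCCCNc1ccnc2cc(-c3ccc(C(C)(C)C)cc3)ccc12`, differs from compound 1 at the other end: 5-fluoro-2-methoxyphenyl in place of 2-hydroxy-3-methoxyphenyl on a saturated chain carbon bound to an amine nitrogen. For the measured compounds named here, no measured step touches this position, so none of the three steps bears directly on it. What the series does show is that single changes of a group of comparable size have moved this assay by modest amounts, none beyond the largest step from compound 1 to compound 3. The expectation for compound 4 is therefore a step of a 1.8-fold lower number from compound 1 to compound 4 (0.25 log units; within the scatter), a modest lowering or no change beyond the scatter. Compound 4 is estimated at 18000 nM, with a range from 7000 nM to 45000 nM.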

Compound 4, solubility: 32000 nM
The estimate for compound 4 lay 1.8-fold (0.25 log units) below the measured number; the measured number falls inside the stated range.
By their numbers in this assay, from the lowest: compound 3; then compound 2; then compounds 1 and 4 (each within the scatter of the next).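

In this assay the benzylamine end now has its first reading, since all earlier steps changed the group on the aromatic carbon: 5-fluoro-2-methoxyphenyl in place of 2-hydroxy-3-methoxyphenyl gives no change at the digits printed from compound 1 to compound 4 (within the scatter) with 4-(tert-butyl)phenyl held constant. At this position, on a saturated chain carbon bound to an amine nitrogen, the exchange removes the hydrogen-bond donor of the leaving group and still shows no step beyond the scatter. Nothing measured here accounts for this result.

From the compounds shown here alone, whether the same exchange reads alike with 3-methoxyphenoxy or 3-(trifluoromethyl)benzyl on the aromatic carbon remains open. Also open, going by these compounds, is how this read-out responds at the same position to a phenyl ring carrying a carboxylic acid or a dimethylamino group, or to a longer chain.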